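From Compound 2 to Its Chlorine-Bearing Relative, Compound 4

A few compounds are considered here, and "the series" means these few. Any claim that something is new, unique, unknown or untested is made for them only; others in the source may bear on it.

Measured in a functional assay on HeLa cells (Homo sapiens) for antiproliferative activity, read by MTT assay, with a stated time of 72 h; a higher number here means a weaker inhibitor, a lower number a stronger inhibitor:
- compound 1 `O=C1O/C(=C\Cn2cnc3ccn(C/C=C4\OC(=O)C(OCc5ccccc5)=C4OCc4ccccc4)c3c2=O)C(OCc2ccccc2)=C1OCc1ccccc1`: 5600 nM
- compound 2 `O=C1O/C(=C\Cn2cnc3cc[nH]c3c2=O)C(OCc2ccccc2)=C1OCc1ccccc1`: 27000 nM
- compound 3 `O=C1NC(O)(CCn2cnc3ccnc(Cl)c32)C(OCc2ccccc2)=C1OCc1ccccc1`: 21000 nM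

Not yet measured: compound 4 `O=C1O/C(=C\Cn2cnc3ccnc(Cl)c32)C(OCc2ccccc2)=C1OCc1ccccc1`.

Compound 2, at 27000 nM, lies within the scatter of compound 3. Compound 1 reads lower, beyond the scatter, so it is the stronger inhibitor of that pair. Compound 4 differs from compound 2 by one exchange: a group of 10 heavy atoms (6 carbon, 3 nitrogen, 1 chlorine; one five-membered aromatic ring with 2 hetero atoms, one six-membered aromatic ring with 1 hetero atom) in place of a group of 10 heavy atoms (6 carbon, 3 nitrogen, 1 oxygen; one five-membered aromatic ring with 1 hetero atom, one six-membered aromatic ring with 2 hetero atoms), on a saturated chain carbon bound to a double-bonded chain carbon. Compound 3 already carries the entering group, on a different remainder, and gives 21000 nM. That single value offers only weak guidance, so little change beyond the scatter is expected in this assay, with any shift likely toward a lower number. The expected step is a 1.8-fold lower number from compound 2 to compound 4 (0.26 log units; within the scatter). For compound 4 the estimated value is 15000 nM, with an expected range from 4000 nM to 40000 nM.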

Compound 4, half-maximal inhibitory concentration: > 100000 nM
Compound 4: a limit, no number; the forecaster's own chance of this, stated with the estimate: 15%; middle value at least 6.6-fold (0.82 log units) away from the limit.
By their numbers in this assay, from the lowest: compound 1; then compounds 3 and 2 (each within the scatter of the next). At a limit, above all of these: compound 4.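

The exchange on a saturated chain carbon bound to a double-bonded chain carbon is the first change shown between compounds that differ in one place, and it gives an at least 3.7-fold higher number from compound 2 to compound 4 (0.56 log units; beyond the scatter) in this assay and leaves the chlorine-bearing compound the weaker of the pair. The reading for compound 4 is a limit, not a number: the limit of > 100000 nM in this assay, at which 1 of the 4 values shown sits.

The exchange alters the chlorine and the ring hetero atoms together, leaving open which of these changes carries the loss. On these data alone, whether an amine or a methoxy group in place of the chlorine would regain activity also remains open.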